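This account rests on a few compounds, and the source may have more. Where it says the series, first, only, none or still open, it means among the compounds named here.

Values in a functional assay on A549 cells (Homo sapiens) for cytotoxicity, read by MTT assay, with a stated time of 72 h; a lower number here means a stronger inhibitor, a higher number a weaker inhibitor:
Compound 1 `Cc1ccc(Cn2cc(/C=N/NC(=O)Nc3nc4ccc(CN5CCC(C)CC5)cc4s3)c3ccccc32)cc1`: 2180 nM
Compound 2 `CC1CCN(Cc2ccc3nc(NC(=O)N/N=C/c4cn(Cc5ccccc5Cl)c5ccccc45)sc3c2)CC1`: 3330 nM
Compound 3 `CCN(CC)Cc1ccc2nc(NC(=O)N/N=C/c3cn(Cc4ccccc4)c4ccccc34)sc2c1`: 3330 nM
Compound 4 `CC1CCN(Cc2ccc3nc(NC(=O)N/N=C/c4cn(Cc5ccccc5)c5ccccc45)sc3c2)CC1`: not yet measured

Compound 3, at 3330 nM, stands level with compound 2 at the digits shown, and compound 1 lies within the scatter of both, so the three measured compounds do not separate.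

The next step leads to compound 4, with 4-methylpiperidin-1-yl in place of diethylamino on a saturated chain carbon bound to an aromatic carbon. For the measured compounds named here, no measured step tests this exchange directly. Going by the values given here, the only measured step, a 1.5-fold higher number from compound 1 to compound 2 (0.18 log units; within the scatter), lies elsewhere, on a saturated chain carbon bound to an aromatic nitrogen, and it bears on this change only indirectly: it shows little movement in this small set. More relevant, compound 1 and compound 2 already carry 4-methylpiperidin-1-yl, and their values fall within the scatter of compound 3. With only these compounds to go on, no step beyond the scatter is expected in this assay, in either direction. The estimated step is small (a 1.3-fold lower number from compound 3 to compound 4 (0.11 log units; within the scatter)). The expected value for compound 4 is 2600 nM, with an estimated range from 1300 nM to 5000 nM.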

Compound 4, half-maximal inhibitory concentration: 2340 nM
The estimate for compound 4 lay 1.1-fold (0.05 log units) above the measured number; measured number inside the range.
By their numbers in this assay, from the lowest: compounds 1, 4, 2 and 3 (each within the scatter of the next).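

In this assay, the exchange of diethylamino for 4-methylpiperidin-1-yl on a saturated chain carbon bound to an aromatic carbon now has a direct test (a 1.4-fold lower number from compound 3 to compound 4 (0.15 log units; within the scatter)), and the open-chain amine and the six-membered ring do not separate in this read-out. For the compounds shown here, compound 4 also gives the first direct comparisons of hydrogen with the two substituents on an aromatic carbon, with 4-methylpiperidin-1-yl held constant: chloro (a 1.4-fold lower number from compound 2 to compound 4 (0.15 log units; within the scatter)) and methyl (a 1.1-fold higher number from compound 1 to compound 4 (0.03 log units; within the scatter)) do not separate from hydrogen there. No additional measurement on these compounds bears on the result.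

Every step among the compounds shown lies within the scatter, so they give no group at either place that shifts the number beyond it. Still open, as far as these compounds go, is whether morpholine on the saturated chain carbon bound to an aromatic carbon, or a carboxylic acid or methoxy group on the aromatic carbon now carrying hydrogen in compound 4, would give a step beyond the scatter in this assay.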